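Removing a hydroxy group from a biaryl side chain

This account rests on a few compounds, and the source may have more. Where it says the series, first, only, none or still open, it means among the compounds named here.

Measured compounds:
compound 1 `CC[C@@H](Nc1c(C#N)c(-c2ccc(-c3ccccc3CO)cc2)nc2cnccc12)C(N)=O`: 2.1
compound 2 `CC[C@@H](Nc1c(C#N)c(-c2ccc(-c3ccccc3OC)cc2)nc2cnccc12)C(N)=O`: 2.7
compound 3 `CC[C@@H](Nc1c(C#N)c(-c2ccc(-c3cccc(CO)c3)cc2)nc2cnccc12)C(N)=O`: 2

In a physicochemical assay for lipophilicity, read by HPLC, at pH 7.5 (a higher number here means a more lipophilic compound, a lower number a more polar compound), compound 3 gives the lowest of the three numbers; compound 1 stands nearest, a number 0.10 log units lower from compound 1 to compound 3 (within the scatter), and compound 2 stands furthest, a number 0.70 log units lower from compound 2 to compound 3 (beyond the scatter). Compound 4 `CC[C@@H](Nc1c(C#N)c(-c2ccc(-c3cccc(C)c3)cc2)nc2cnccc12)C(N)=O` differs from compound 3 in one place: hydrogen in place of hydroxy on a saturated chain carbon bound to an aromatic carbon. The step that bears most on this change is a number 0.60 log units higher from compound 1 to compound 2 (beyond the scatter), where a hydroxy-bearing group was likewise exchanged for one without it. The other two steps only move the hydroxymethyl around the ring. A rise beyond the scatter in this assay is therefore expected, probably somewhat larger than that step, since here nothing polar enters at all. Compound 4 is estimated at 3, between 2.6 and 3.4, a step of a number 1.00 log units higher from compound 3 to compound 4 (beyond the scatter).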

Compound 4, distribution coefficient: 3
Compound 4: the middle estimate sits on the measured number at the digits printed; the range from low to high includes it.
By their numbers in this assay, from the lowest: compounds 3 and 1 (each within the scatter of the next); then compounds 2 and 4 (each within the scatter of the next).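

In this assay, the change from 3-(hydroxymethyl)phenyl to 3-methylphenyl (a number 1.00 log units higher from compound 3 to compound 4 (beyond the scatter)) shows that losing the hydroxy alone, with no heavy atom entering, moves the number beyond the scatter. The change from 2-(hydroxymethyl)phenyl to 3-methylphenyl also goes beyond it (a number 0.90 log units higher from compound 1 to compound 4 (beyond the scatter)), whereas the change from 2-methoxyphenyl to 3-methylphenyl stays within it (a number 0.30 log units higher from compound 2 to compound 4 (within the scatter)). Nothing given here accounts for the size of these steps.

On these data alone, how an amine or a carboxylic acid on this saturated chain carbon would read in this assay remains open.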